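The source may report more compounds than this note shows. Statements on the series, on what has been measured and on what is new or still open speak of the compounds shown alone.

Measured so far:
- Compound 1, `Cc1ccc([C@H](C(=O)N(C)C)N2C(=O)[C@@H](C3Cc4ccccc4C3)NC(=O)[C@H]2CC(C)C)cn1`: 1.59 nM
- Compound 2, `Cc1ccc([C@H](C(=O)N2CCCC2)N2C(=O)[C@@H](C3Cc4ccccc4C3)NC(=O)[C@H]2CC(C)C)cn1`: 0.501 nM

Both were tested in an assay on isolated protein for displacement of a labelled ligand from Oxytocin receptor (Homo sapiens); a lower number here means a stronger inhibitor, a higher number a weaker inhibitor. Among the two numbers, compound 1 has the higher one; its only neighbour is compound 2, and the step of a 3.2-fold lower number from compound 1 to compound 2 (0.50 log units; beyond the scatter) came from putting pyrrolidin-1-yl in place of dimethylamino on a carbonyl carbon.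

The compound now in question is compound 3, `Cc1ccc([C@H](C(=O)N(C)C)N2C(=O)[C@@H](C3Cc4ccccc4C3)NC(=O)[C@H]2CC(C)(C)C)cn1`. It keeps the dimethylamino group of compound 1 and differs from it elsewhere: methyl in place of hydrogen on a saturated chain carbon bound to three saturated chain carbons. Cut one bond further out, this reads as isobutyl to neopentyl.

Going by the values given here, no measured step touches this place. Among the compounds with values here, the one step known, from compound 1 to compound 2, changes the amide end and so says nothing about what adding a methyl on the saturated chain carbon does. The expectation therefore has little to lean on: a step near or within the usual scatter seems as likely as a real loss, and a gain cannot be ruled out. On balance a small rise in the number is expected, a 1.6-fold higher number from compound 1 to compound 3 (0.20 log units; within the scatter), with compound 3 estimated at 2.5 nM, within a range of 0.6 nM to 10 nM.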

Compound 3, inhibition constant in the Oxytocin receptor assay: 0.0631 nM
Compound 3: middle estimate off by 40-fold (1.60 log units), on the high side; measured number outside the range, below it.
By their numbers in the Oxytocin receptor assay, from the lowest: compound 3; then compound 2; then compound 1.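

Going by these compounds alone, in the Oxytocin receptor assay, the earlier compounds showed only a change at the amide end, whereas this pair shows that the isobutyl side of the core also matters: one methyl in place of hydrogen on a saturated chain carbon bound to three saturated chain carbons, turning isobutyl into neopentyl, gives a 25-fold lower number from compound 1 to compound 3 (1.40 log units; beyond the scatter). In a physicochemical assay for solubility, read by HPLC (on this read-out higher numbers stand for higher solubility and lower numbers for lower solubility), compound 1 gives > 236 ug/mL, which is a limit of the assay and not a number. In the physicochemical assay, compound 3 gives > 242 ug/mL, which is also a limit and not a number, so the step in solubility between these two compounds cannot be read.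

Going by these compounds, it remains open whether the same methyl gives a step of similar size when pyrrolidin-1-yl, as in compound 2, replaces dimethylamino on the carbonyl carbon. On these data alone, it is also open whether the gain is specific to neopentyl or extends to other groups at this place, such as a longer chain, a cyclohexyl ring or a trifluoromethyl group.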